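The source may report more compounds than this note shows. Statements on the series, on what has been measured and on what is new or still open speak of the compounds shown alone.

Measured in an assay on frontal cortex for displacement of a labelled ligand from corticotropin-releasing factor receptor 1 (Rattus norvegicus), with a stated time of 2 h; on this read-out higher numbers stand for weaker inhibition and lower numbers for stronger inhibition:
Compound 1, `COc1nc(C)c(Nc2nc(Cl)cn([C@H](COC(=O)c3cccnc3)C3CC3)c2=O)cc1C`: 5.2 nM
Compound 2, `COc1nc(C)c(Nc2nc(Cl)cn([C@H](COC(=O)Nc3ccc(Cl)cc3)C3CC3)c2=O)cc1C`: 1.6 nM
Compound 3, `COc1nc(C)c(Nc2nc(Cl)cn([C@H](COC(=O)Nc3cccc(C#N)c3)C3CC3)c2=O)cc1C`: 1.3 nM

Compound 3 gives the lowest number of the three; compound 2 sits within the scatter of it, while compound 1 lies beyond it, as a 4.0-fold lower number from compound 1 to compound 3 (0.60 log units; beyond the scatter) shows. Compound 4, `COc1nc(C)c(Nc2nc(Cl)cn([C@H](COc3cccnc3)C3CC3)c2=O)cc1C`, differs from compound 3 at the oxygen on the saturated carbon: pyridin-3-yl in place of (3-cyanophenyl)carbamoyl on an oxygen on a saturated carbon. For the measured compounds named here, no measured step changes that position in this way. The steps of a 3.3-fold lower number from compound 1 to compound 2 (0.51 log units; beyond the scatter) and a 4.0-fold lower number from compound 1 to compound 3 (0.60 log units; beyond the scatter) only exchange groups on the carbonyl carbon, and a 1.2-fold lower number from compound 2 to compound 3 (0.09 log units; within the scatter) exchanges groups on the amide-type nitrogen; the carbonyl itself is kept in every measured compound. The removal of the whole (3-cyanophenyl)carbamoyl group is outside what the data cover, so a step toward a higher number, of modest size, is expected for compound 4, as a 6.2-fold higher number from compound 3 to compound 4 (0.79 log units; beyond the scatter). Compound 4 is estimated at 8 nM, within 2 nM to 40 nM in this assay.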

Compound 4, half-maximal inhibitory concentration: 6.7 nM
For compound 4 the middle estimate is 1.2-fold (0.08 log units) above the measured one; the measured number falls inside the stated range.
By their numbers in this assay, from the lowest: compounds 3 and 2 (each within the scatter of the next); then compounds 1 and 4 (each within the scatter of the next).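

In this assay, for the compounds shown here, the carbonyl on the oxygen is lost for the first time, and against the two carbamates inhibition weakens: a 5.2-fold higher number from compound 3 to compound 4 (0.71 log units; beyond the scatter) and a 4.2-fold higher number from compound 2 to compound 4 (0.62 log units; beyond the scatter). Against the ester, the same loss of the carbonyl leaves the pyridin-3-yl group with no change outside the scatter, a 1.3-fold higher number from compound 1 to compound 4 (0.11 log units; within the scatter), so at this position the carbonyl alone does not separate these compounds. No measurement here bears on why these steps take this form. Going by these compounds, it remains open whether 3-cyanophenyl on the oxygen, or a free hydroxyl group, would fall with compound 4 or with the carbamates.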